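Working notes: from compound 2 to compound 3

The source may hold more compounds than are shown below. What is called first, only, known or untested is meant among the compounds shown, and "the series" means these compounds.

Measured in a functional assay on K562 cells (Homo sapiens) for antiproliferative activity, with a stated time of 72 h (on this read-out higher numbers stand for weaker inhibition and lower numbers for stronger inhibition), so far
- compound 1 `OC[C@H]1O[C@@H](n2cnc3c(NCc4cccc(F)c4)ncnc32)[C@H](O)[C@@H]1O` gives 7600 nM
- compound 2 `Cc1cccc(CNc2ncnc3c2ncn3[C@@H]2O[C@H](CO)[C@@H](O)[C@H]2O)c1` gives > 166000 nM as a limit

Compound 2 has no number, only the limit > 166000 nM of this assay. Compound 3 `COc1ccc(CNc2ncnc3c2ncn3[C@@H]2O[C@H](CO)[C@@H](O)[C@H]2O)c(OC)c1` carries 2,4-dimethoxyphenyl in place of 3-methylphenyl on a saturated chain carbon bound to a nitrogen on an aromatic ring. Within the data shown here, the one measured step that bears on this is an at least 21-fold higher number from compound 1 to compound 2 (1.33 log units; beyond the scatter) and it is large, so a large step towards a lower number is expected in this assay. The expected change is an at least 3.3-fold lower number from compound 2 to compound 3 (0.52 log units; beyond the scatter). For compound 3 the estimated value is 50000 nM with a range of 10000 nM to 160000 nM.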

Compound 3, half-maximal inhibitory concentration: > 166000 nM
Compound 3 was reported as a limit; the forecaster's own chance of this, stated with the estimate: 45%; middle value at least 3.3-fold (0.52 log units) away from the limit.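

In this assay, a second replacement of 3-fluorophenyl, this time by 2,4-dimethoxyphenyl, gives an at least 21-fold higher number from compound 1 to compound 3 (1.33 log units; beyond the scatter). With compound 2 and compound 3 both reported only as limits, neither replacement tested here retains a readable value, although they differ in the group entering at this position. The step between compound 2 and compound 3 cannot be read, because neither has a number: the limit of > 166000 nM in this assay, at which 2 of the 3 values shown sit.

Open, from the compounds shown here alone, is whether the fluoro group itself is required or whether another group at this place, such as chloro or an amine, also gives a measurable value.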